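The compounds below may be only part of what the source reports. "The series", "measured", "known", "first", "only" and "open" are said of these compounds alone.

Measured compounds in an ADME assay on liver (Rattus norvegicus, strain Wistar) for metabolic stability, read by HPLC, tested at 200 uM; on this read-out higher numbers stand for a longer-lived compound and lower numbers for a shorter-lived compound (half-life):
- compound 1 (`Cc1cc(OC(=O)C(C)(C)CCC(CO[N+](=O)[O-])O[N+](=O)[O-])n(-c2ccccc2)n1`): (0.05 h)
- compound 2 (`Cc1cc(OC(=O)C(C)(C)CO[N+](=O)[O-])n(-c2ccccc2)n1`): (< 0.0167 h)
- compound 3 (`Cc1cc(OC(=O)c2ccc(CCCO[N+](=O)[O-])cc2)n(-c2ccccc2)n1`): (< 0.0167 h)

Compound 2 has no number here, only a limit (< 0.0167 h). Compound 3 also gives only a limit (< 0.0167 h). Taken together, the set shows (the limit of < 0.0167 h in this assay, at which 2 of the 3 values shown sit). Compound 1 alone gives a number (0.05 h), so the position of compound 2 is known only from one side.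

The next compound to be read is compound 4 (`Cc1cc(OC(=O)C(C)(C)CCCCO[N+](=O)[O-])n(-c2ccccc2)n1`). It carries 3-(nitrooxy)propyl in place of nitrooxy on a saturated chain carbon, two bonds along the chain from a carbonyl carbon. Cut one bond further out, the same difference reads (nitrooxy)methyl to 4-(nitrooxy)butyl.

Within the data shown here, no step between measured compounds is available to size this change. Among the measured compounds shown here, the only guide is the single number in the set, from compound 1 (0.05 h), so the expectation is loose. A small upward move toward a longer-lived compound is expected (an at least 2.3-fold higher number from compound 2 to compound 4 (0.37 log units; beyond the scatter)), and a second limit reading remains a real possibility. Compound 4 is estimated at (0.04 h), with an expected range from (0.0167 h) to (0.1 h).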

Compound 4, half-life in the liver assay: 0.0333 h
Compound 4: the middle estimate sits 1.2-fold (0.08 log units) above what was measured, and the stated range covers the measured number.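

In the liver assay, 3-(nitrooxy)propyl in place of nitrooxy on this saturated chain carbon, two bonds along the chain from a carbonyl carbon, gives a countable half-life rather than a limit, and the step reads an at least 1.9-fold higher number from compound 2 to compound 4 (0.29 log units; that floor lies within the scatter); this position therefore tolerates the longer group, but the size of the step cannot be separated from the scatter. The comparison with the doubly nitrated chain gives a 1.5-fold lower number from compound 1 to compound 4 (0.18 log units; within the scatter), so hydrogen in place of the second nitrooxy leaves no readable difference. In a physicochemical assay for lipophilicity, read by HPLC, measured as octanol-water partition, at pH 7 (a lower number here means a more polar compound, a higher number a more lipophilic compound), compound 2 gives 3.55 and compound 4 gives 4.3 for the same change from nitrooxy to 3-(nitrooxy)propyl, and any link between this partition coefficient and half-life rests on this single pair and cannot be separated from the change in chain: the measured partition coefficient of compound 2, 3.55, and of compound 4, 4.3, a number 0.75 log units higher (beyond the scatter)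

Going by these compounds, with so many readings at the bottom of the scale, differences among the shortest-lived compounds stay unresolved: the limit of < 0.0167 h in the liver assay, at which 2 of the 4 values shown sit. Whether an amide in place of the ester, or a longer chain than 4-(nitrooxy)butyl, would give a half-life clearly beyond the scatter of these values remains open.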